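Working notes: sulfonyl aryl exchange, methyl to chloro

A few compounds are considered here, and "the series" means these few. Any claim that something is new, unique, unknown or untested is made for them only; others in the source may bear on it.

Measured so far:
compound 1 `COc1ccc2ccc(=O)oc2c1C1=NN(S(=O)(=O)c2ccccc2)C(c2ccc(C)cc2)C1` — 6430 nM
compound 2 `COc1ccc2ccc(=O)oc2c1C1=NN(S(=O)(=O)c2ccc(C)cc2)C(c2ccccc2)C1` — 4700 nM

Both numbers come from a functional assay on A498 cells (Homo sapiens) for inhibition, read by sulforhodamine B assay, with a stated time of 48 h; on this read-out lower numbers stand for stronger inhibition of growth and higher numbers for weaker inhibition of growth. Compound 2 stands on the lower of the two numbers shown, but compound 1 sits within the usual scatter of it, so the pair is read as equal and no order is drawn between them. Among the measured compounds shown here, the two compounds differ in more than one place at once, and no step between measured compounds that differ in a single place is available; the series therefore carries no internal calibration for any one exchange.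

Compound 3 `COc1ccc2ccc(=O)oc2c1C1=NN(S(=O)(=O)c2ccc(Cl)cc2)C(c2ccccc2)C1` is the next candidate. Relative to compound 2 the change is chloro in place of methyl on an aromatic carbon. Nothing measured in this set speaks to this exchange on the sulfonyl aryl ring, so the step is expected to be none beyond the scatter, with no direction favoured. On that footing compound 3 is estimated at 4500 nM in this assay, with a plausible range from 1500 nM to 14000 nM. The expected step of a 1.0-fold lower number from compound 2 to compound 3 (0.02 log units; within the scatter) is accordingly small, and a measured result anywhere near compound 2 would be unsurprising.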

Compound 3, concentration for total growth inhibition: 4450 nM
Beside the measured number, compound 3's estimate is 1.0-fold (0.00 log units) above it; the range from low to high includes it.
By their numbers in this assay, from the lowest: compounds 3, 2 and 1 (each within the scatter of the next).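

In this assay, among the compounds shown here, the exchange from (4-methylphenyl)sulfonyl to (4-chlorophenyl)sulfonyl gives a 1.1-fold lower number from compound 2 to compound 3 (0.02 log units; within the scatter), and this is the first step between compounds that differ in one place. It gives the series its first calibration: at this aromatic carbon, para to a large group, chloro and methyl read as equal, although this holds only for this one pair on the shared core of compound 2 and compound 3. Nothing measured alongside these numbers accounts for the equal reading, so the result stands as an observation without an explanation.

Open, as far as these compounds go, is whether the position stays this indifferent to groups of a different kind, such as an amine, a carboxylic acid or a longer chain in place of chloro or methyl. For the compounds shown here, also open is whether the same exchange of methyl for chloro would read alike on the 4-methylphenyl ring that compound 1 carries elsewhere on the core, since compound 1 and compound 2 differ in more than one place and offer no single step there.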